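Nitroaryl serinol anilines: trifluoromethyl in place of nitro

The compounds below may be only part of what the source reports. "The series", "measured", "known", "first", "only" and "open" are said of these compounds alone.

Compound 1, `O=[N+]([O-])c1ccccc1NC(CO)CO`, in a functional assay on HCT-116 cells (Homo sapiens) for cytotoxicity (a lower number here means a stronger inhibitor, a higher number a weaker inhibitor), gives > 100000 nM.
Compound 2, `O=[N+]([O-])c1ccc(NC(CO)CO)c([N+](=O)[O-])c1`, in this assay gives > 100000 nM.
Compound 3, `O=[N+]([O-])c1cc(C(F)(F)F)ccc1NC(CO)CO`, is not yet measured in this assay.

The value for compound 1 is a limit of the assay, not a number. The value for compound 2 is likewise a limit of the assay. What the measurements show comes down to the limit of > 100000 nM in this assay, at which 2 of the 2 values shown sit. Among the compounds with values here, compound 2 therefore stands at the limit in this assay, with no number attached, and the single measured step, a step that the two limits leave unreadable from compound 1 to compound 2, cannot be read in size or direction.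

Compound 3 differs from compound 2 by trifluoromethyl in place of nitro on an aromatic carbon. Within the data shown here, the only measured step that bears on this change is the one from compound 1 to compound 2, and its size is not readable; no measured pair shows nitro replaced by trifluoromethyl. No direction in this assay can be set from the data, and the working expectation is that compound 3 stays near the limit. Compound 3 is estimated at 150000 nM, with a range from 30000 nM to 1000000 nM. The implied step that the limit leaves unreadable from compound 2 to compound 3 is expected to remain within the scatter.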

Compound 3, half-maximal inhibitory concentration: > 100000 nM
Compound 3 gave a limit, no number (the forecaster's own chance of this, stated with the estimate: 75%); the middle value is on the limit's open side.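

No new step can be read among compound 1, compound 2 and compound 3 in this assay, as each value is a limit of the assay and not a number: the limit of > 100000 nM in this assay, at which 3 of the 3 values shown sit.

The compounds shown leave open how hydrogen, nitro and trifluoromethyl on this aromatic carbon of the shared core compare in this assay.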